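The compounds below may be only part of what the source reports. "The series", "measured", "known", "first", "only" and "open" are said of these compounds alone.

Compound 1, `COc1ccccc1N1CCN(C(=S)SCC(O)Cn2c([N+](=O)[O-])cnc2C)CC1`: in a toxicity assay on HeLa cells (Homo sapiens) for cytotoxicity, read by MTT assay, with a stated time of 24 h (on this read-out higher numbers stand for weaker inhibition and lower numbers for stronger inhibition), compound 1 gives > 5000000 nM.
Compound 2, `Cc1ncc([N+](=O)[O-])n1CC(O)CSC(=S)N1CCC(C)CC1`: in this assay compound 2 gives 1820000 nM.

For compound 1 the value is a limit of the assay, not a number, as the limit of > 5000000 nM in this assay, at which 1 of the 2 values shown sits, shows, so compound 1 stands only as a boundary. Compound 3, `CCCCN1CCN(C(=S)SCC(O)Cn2c([N+](=O)[O-])cnc2C)CC1`, differs from compound 1 by butyl in place of 2-methoxyphenyl on an amine nitrogen in a ring. Within the data shown here, no measured pair shows this change, so the expectation rests on the two values alone. The step from compound 1 to compound 3 is expected to be an at least 1.6-fold lower number from compound 1 to compound 3 (0.22 log units; that floor lies within the scatter), within scatter or toward slightly stronger inhibition. Compound 3 is estimated at 3000000 nM, between 1000000 nM and 10000000 nM.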

Compound 3, half-maximal inhibitory concentration: 1910000 nM
Compound 3: middle estimate off by 1.6-fold (0.20 log units), on the high side; measured number inside the range.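

On the amine nitrogen in the ring, butyl in place of 2-methoxyphenyl gives an at least 2.6-fold lower number from compound 1 to compound 3 (0.41 log units; beyond the scatter) in this assay, so this position does respond to the change, toward stronger inhibition. The value of compound 1 is a limit of the assay, not a number, so the step has only a floor: the limit of > 5000000 nM in this assay, at which 1 of the 3 values shown sits.

The compounds shown leave open whether the step follows from losing the aromatic ring or only the methoxy group, which a plain phenyl would separate. Going by these compounds, how a longer chain or a chain ending in an amine would read also stays open.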